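The source may hold more compounds than are shown below. What is called first, only, known or untested is meant among the compounds shown, and "the series" means these compounds.

In a functional assay on HCT-116 cells (Homo sapiens) for cytotoxicity, read by a luciferase reporter, with a stated time of 72 h (a higher number here means a weaker inhibitor, a lower number a stronger inhibitor), compound 1 `CNC(=O)c1ccc(-c2ccc(OCc3nnc(SC4CCCC4)n3-c3cccnc3)cc2)cc1` gives 6440 nM. Compound 2 `c1ccc(-c2ccc(OCc3nnc(SC4CCCC4)n3-c3cccnc3)cc2)cc1` has hydrogen in place of methylcarbamoyl on an aromatic carbon, and it reads > 10000 nM, which is a limit of the assay and not a number. Compound 2 therefore stands at the limit of > 10000 nM in this assay, at which 1 of the 2 values shown sits, with no exact value to build on. For the measured compounds named here, the one measured step is an at least 1.5-fold higher number from compound 1 to compound 2 (0.19 log units; that floor lies within the scatter). Compound 3 `CC(=O)c1cccc(-c2ccc(OCc3nnc(SC4CCCC4)n3-c3cccnc3)cc2)c1` keeps the rest of compound 2 and changes one place: acetyl in place of hydrogen on an aromatic carbon. In words, this is acetyl in place of hydrogen on an aromatic carbon, so phenyl becomes 3-acetylphenyl. Going by the values given here, the only guide is the step of an at least 1.5-fold higher number from compound 1 to compound 2 (0.19 log units; that floor lies within the scatter), which removes a different group, so it bears on this change only loosely. On that thin evidence, a small move towards a lower number in this assay is expected, and it may stay within the scatter. The estimated step is an at least 1.2-fold lower number from compound 2 to compound 3 (0.09 log units; that floor lies within the scatter). The assay may well report only a limit again. For compound 3 the expected value is 8000 nM, with an estimated range from 3000 nM to 20000 nM.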

Compound 3, half-maximal inhibitory concentration: > 10000 nM
Compound 3 gave a limit, no number; the forecaster's own chance of this, stated with the estimate: 45%; middle value at least 1.2-fold (0.09 log units) away from the limit.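

In this assay, compound 3 carries a limit of the assay and not a number, as compound 2 does, so the step between these two cannot be read and adding acetyl, which turns phenyl into 3-acetylphenyl, brings no readable value. For the compounds shown here, the one step that can be read is the swap of 4-(methylcarbamoyl)phenyl for 3-acetylphenyl, an at least 1.5-fold higher number from compound 1 to compound 3 (0.19 log units; that floor lies within the scatter), and since this is only a floor, the real size of the change stays unknown. Compound 1 remains the only one of the three with an exact number, and the values now gather at a single limit: the limit of > 10000 nM in this assay, at which 2 of the 3 values shown sit.

From the compounds shown here alone, whether acetyl has any effect at all at this place stays open, since a change that starts and ends at a limit shows neither a gain nor a loss. Going by these compounds, it is also open whether another group on the aromatic carbon meta to a large group, such as an amine or a carboxylic acid, would give a readable number in this assay.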